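Moving a hydroxyl on a pyridyl-bearing core

The compounds below may be only part of what the source reports. "The series", "measured", "known", "first", "only" and "open" are said of these compounds alone.

Compound 3 `Oc1ccc(-c2cc(-c3ccccn3)cc(-c3ccccc3O)n2)cc1` has been tested in a functional assay on T47D cells (Homo sapiens) for cytotoxicity, read by CCK-8 assay; on this read-out higher numbers stand for weaker inhibition and lower numbers for stronger inhibition. In this assay compound 3 gives only a limit, > 50000 nM. That limit is the one recorded as the limit of > 50000 nM in this assay, at which 1 of the 3 values shown sits. Two related compounds that carry a different group at the same position give numbers instead: compound 1 `Oc1ccc(-c2cc(-c3cccs3)cc(-c3ccc(O)cc3)n2)cc1` gives 11700 nM, and compound 2 `Oc1ccc(-c2cc(-c3ccoc3)cc(-c3ccc(O)cc3)n2)cc1` gives 3460 nM. Within the data shown here, the single measured step, a 3.4-fold lower number from compound 1 to compound 2 (0.53 log units; beyond the scatter), swaps furan-3-yl for thiophen-2-yl and does not touch a hydroxyphenyl group. Compound 4 `Oc1ccc(-c2cc(-c3ccccn3)cc(-c3ccc(O)cc3)n2)cc1` differs from compound 3 by 4-hydroxyphenyl in place of 2-hydroxyphenyl on an aromatic carbon, so compound 4 carries the same pair of 4-hydroxyphenyl groups as compound 1 and compound 2. Among the measured compounds shown here, no measured step tests this change directly, so the expectation rests on compound 1 and compound 2 having numbers rather than a limit. Compound 4 is therefore expected near those two, at 15000 nM, within 3000 nM to 60000 nM. That estimate means a step of an at least 3.3-fold lower number from compound 3 to compound 4 (0.52 log units; beyond the scatter).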

Compound 4, half-maximal inhibitory concentration: 1040 nM
Compound 4: middle estimate off by 14-fold (1.16 log units), on the high side; measured number outside the range, below it.
By their numbers in this assay, from the lowest: compound 4; then compound 2; then compound 1. At a limit, above all of these: compound 3.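

In this assay, replacing 2-hydroxyphenyl with 4-hydroxyphenyl keeps the same atoms yet gives an at least 48-fold lower number from compound 3 to compound 4 (1.68 log units; beyond the scatter), so where the hydroxyl sits on this ring clearly matters. With both 4-hydroxyphenyl groups in place, the remaining group matters too: pyridin-2-yl in place of furan-3-yl gives a 3.3-fold lower number from compound 2 to compound 4 (0.52 log units; beyond the scatter), and pyridin-2-yl in place of thiophen-2-yl gives an 11-fold lower number from compound 1 to compound 4 (1.05 log units; beyond the scatter), so pyridin-2-yl carries the lowest number of the three groups compared there. Compound 3 stands at a limit, so the first step gives only a minimum size: the limit of > 50000 nM in this assay, at which 1 of the 4 values shown sits.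

As far as these compounds go, whether a methoxy group or an amine could replace the hydroxyl on the 4-hydroxyphenyl group and keep the low number remains open. Also open, from the compounds shown here alone, is whether 2-hydroxyphenyl would cost as much alongside furan-3-yl or thiophen-2-yl.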